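The source may report more compounds than this note shows. Statements on the series, on what has been measured and on what is new or still open speak of the compounds shown alone.

Going by the values given here, compound 1 `O=C(COc1ccc2c(=O)ccoc2c1)Nc1cccc(NC(=O)c2ccc(F)cc2)c1` is the one member of this small set with a measured number: in an assay on isolated protein for inhibition of Rho-associated protein kinase 1 (Homo sapiens), read by scintillation counting, radiometric assay and 33P incorporation, with a stated time of 40 min, in the presence of a further agent that is not named here (a lower number here means a stronger inhibitor, a higher number a weaker inhibitor), compound 1 gives 129 nM. Compound 2 `O=C(COc1ccc2c(=O)ccoc2c1)Nc1cccc(NS(=O)(=O)c2ccc(C(F)(F)F)cc2)c1` is known only by a limit, for in this assay compound 2 returns > 10000 nM, a bound of the measurement rather than a value. Compound 3 `Cc1cc(NC(=O)COc2ccc3c(=O)ccoc3c2)cc(NC(=O)c2ccc(N(C)C)cc2)c1` is in the same position, since in this assay compound 3 also reaches only the limit > 10000 nM. Compound 3 thus stands at the limit shared with compound 2 (the limit of > 10000 nM in this assay, at which 2 of the 3 values shown sit), and only compound 1 offers a point of comparison with a real number.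

Compound 4 `CN(C)c1ccc(C(=O)Nc2cc(F)cc(NC(=O)COc3ccc4c(=O)ccoc4c3)c2)cc1` differs from compound 3 by fluoro in place of methyl on an aromatic carbon. Among the compounds with values here, no measured pair isolates this change, so its effect cannot be read from the data. Compound 3 is known only by a limit. The step from compound 3 to compound 4 is therefore expected to be an at least 1.6-fold lower number from compound 3 to compound 4 (0.22 log units; that floor lies within the scatter), with considerable uncertainty in either direction. Compound 4 is estimated at 6000 nM, within a range from 1000 nM to 40000 nM, with a fair chance that this assay again reports only a limit.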

Compound 4, half-maximal inhibitory concentration: 49 nM
Compound 4: the middle estimate sits 120-fold (2.09 log units) above what was measured; the measured number lies below the stated range.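

At this position, on an aromatic carbon meta to two large groups, fluoro in place of methyl gives an at least 200-fold lower number from compound 3 to compound 4 (2.30 log units; beyond the scatter). The earlier compounds shown here offered no pair differing in one place, and this step shows that the group at this one position can separate a compound at the limit of this assay from one with a measured number. The size of the step is a floor and not a full measure, for compound 3 is known only by a limit: the limit of > 10000 nM in this assay, at which 2 of the 4 values shown sit.

On these data alone, whether this result is particular to fluoro, or whether a hydrogen, chloro or methoxy at the same position would give a similar number, remains open. Also open, as far as these compounds go, is whether fluoro and methyl would differ as much with an acyl group other than the dimethylaminobenzoyl of compound 3 and compound 4.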